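The source may report more compounds than this note shows. Statements on the series, on what has been measured and on what is new or still open speak of the compounds shown alone.

The four compounds share one core. Compound 1 `Cc1ncc([N+](=O)[O-])n1CCSC(=S)N1CCC(C)CC1` bears a methyl on a saturated ring carbon and gives 190 ug/mL in an ADME assay on HeLa cells (Homo sapiens) for cytotoxicity; on this read-out lower numbers stand for stronger inhibition and higher numbers for weaker inhibition. Compound 2 `Cc1ncc([N+](=O)[O-])n1CCSC(=S)N1CCC(OC(=O)C(Cl)Cl)CC1` reaches only the limit of > 1000 ug/mL in this assay. Compound 3 `Cc1ncc([N+](=O)[O-])n1CCSC(=S)N1CCC(OS(C)(=O)=O)CC1` likewise sits at the limit of > 1000 ug/mL in this assay, a limit at which two of the three values shown stand (the limit of > 1000 ug/mL in this assay, at which 2 of the 3 values shown sit). Compound 4 `Cc1ncc([N+](=O)[O-])n1CCSC(=S)N1CCC(Cc2ccccc2)CC1` has not yet been measured in this assay.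

On the numbers shown, compound 3 can be placed only as a limit, set apart from compound 1 by an at least 5.2-fold higher number from compound 1 to compound 3 (0.72 log units; beyond the scatter). The step to compound 4 is benzyl in place of (methylsulfonyl)oxy on a saturated ring carbon. Bearing on it are an at least 5.2-fold higher number from compound 1 to compound 2 (0.72 log units; beyond the scatter) and an at least 5.2-fold higher number from compound 1 to compound 3 (0.72 log units; beyond the scatter), both moving away from a plain carbon substituent, while a step that the two limits leave unreadable from compound 2 to compound 3 offers no size. Compound 4 returns to a carbon substituent, so an expected step downward, beyond the scatter, is an at least 6.6-fold lower number from compound 3 to compound 4 (0.82 log units; beyond the scatter) in this assay. Compound 4 is therefore estimated at 150 ug/mL, with a range from 40 ug/mL to 700 ug/mL.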

Compound 4, half-maximal inhibitory concentration: > 1000 ug/mL
Compound 4 was reported as a limit; the forecaster's own chance of this, stated with the estimate: 20%; middle value at least 6.6-fold (0.82 log units) away from the limit.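

In this assay, among these compounds, the earlier steps away from compound 1 each brought in a group joined through oxygen, whereas an at least 5.2-fold higher number from compound 1 to compound 4 (0.72 log units; beyond the scatter) comes with benzyl, joined through carbon, on the same saturated ring carbon, so an oxygen link is not required for a shift of this kind. Among the compounds shown here, compound 1, with its methyl, remains the only compound here with a readable value, and the other three all stand at a limit: the limit of > 1000 ug/mL in this assay, at which 3 of the 4 values shown sit. The steps among compound 2, compound 3 and compound 4 cannot be read, so these three groups cannot be ordered.

The compounds shown leave open how far beyond the limit any of these three lies. They also leave open whether an ethyl group, a longer chain or an amine on this ring carbon would give a readable value.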